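Halogen exchange on the aryl urea pair

A few compounds are considered here, and "the series" means these few. Any claim that something is new, unique, unknown or untested is made for them only; others in the source may bear on it.

Measured so far:
compound 1 `CCOC(=O)c1cccc(NC(=O)N[C@@H](C)c2ccccc2)c1` — an ADME assay on the whole organism with Oryza sativa as the target, tested at 1 uM; a lower number here means a stronger effect, a higher number a weaker effect of the compound at the concentration tested: 99%
compound 2 `C[C@H](NC(=O)Nc1cccc(Br)c1)c1ccccc1` — this assay: 100%

Among the measured compounds shown here, compound 2 holds the highest of the two numbers so far, and compound 1 is its nearest neighbour, with a difference a number 1 percentage points higher from compound 1 to compound 2 (within the scatter). Both compounds therefore sit at the weak end of the read-out under these conditions, and the two are not separable from each other.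

The next compound is compound 3 `C[C@H](NC(=O)Nc1cccc(I)c1)c1ccccc1`. Its difference from compound 2 is iodo in place of bromo on an aromatic carbon.

For the measured compounds named here, the only measured step that bears on this change is the exchange of one group on the same aromatic carbon, a number 1 percentage points higher from compound 1 to compound 2 (within the scatter), which stayed within the scatter even though that exchange was between two groups of different kind. Going by the values given here, no step between two halogens has been measured, so the expectation rests on that single comparison. On this basis the step from compound 2 to compound 3 is expected to be a number 1 percentage points lower from compound 2 to compound 3 (within the scatter), that is, nothing beyond the scatter.

Compound 3 is thus estimated to give 99% in this assay, within an expected range of 90% to 100%.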

Compound 3, a percentage reported as activity, at one concentration (the size of the read-out at that concentration, not a potency): 95%
Compound 3: the middle estimate sits 4 percentage points above what was measured; low and high end bracket the measured number.
By their numbers in this assay, from the lowest: compounds 3, 1 and 2 (each within the scatter of the next).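

In this assay, the exchange between two halogens on this aromatic carbon, meta to a large group, gives a number 5 percentage points lower from compound 2 to compound 3 (within the scatter) and so does not separate iodo from bromo. Iodo set against ethoxycarbonyl on the same carbon gives a number 4 percentage points lower from compound 1 to compound 3 (within the scatter) and likewise stays within the scatter, which extends the earlier single comparison: ethoxycarbonyl, bromo and iodo all give readings within the scatter of one another, and none of the three exchanges at this position moves the read-out beyond it. Nothing available on these compounds offers an explanation for this flat picture.

The three compounds leave open whether any group on this carbon can shift the read-out beyond the scatter, for instance an amine, a carboxylic acid or a smaller halogen such as fluoro. Among the compounds shown here, they also leave open whether the urea linker, the methyl group or the unsubstituted phenyl ring of the shared core would respond differently, since all of the steps so far concern a single aromatic carbon.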